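This account rests on a few compounds, and the source may have more. Where it says the series, first, only, none or still open, it means among the compounds named here.

Measured so far in a functional assay on RS4-11 cells (Homo sapiens) for inhibition, read by CCK-8 assay, with a stated time of 48 h, tested at 20 uM; a lower number here means less inhibition of growth, a higher number more inhibition of growth at the concentration tested:

compound 1, `N#C/C(=C\c1ccccc1OS(=O)(=O)c1ccc(Cl)cc1)C(=O)Nc1nnc(Cc2cccc3ccccc23)s1`, 68%
compound 2, `COc1ccc(S(=O)(=O)Oc2ccccc2/C=C(\C#N)C(=O)Nc2nnc(Cc3ccccc3)s2)cc1`, 78%

Compound 2 holds the higher of the two numbers, but the gap to compound 1 lies within the scatter, so the two compounds cannot be ordered on these values. Compound 1 and compound 2 differ in two places at once, so neither place can be given its own share of the gap.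

Compound 3, `N#C/C(=C\c1ccccc1OS(=O)(=O)c1ccc(Cl)cc1)C(=O)Nc1nnc(Cc2ccccc2)s1`, has not yet been measured in this assay. It differs from compound 2 in one place: chloro in place of methoxy on an aromatic carbon. Within the data shown here, no single-point step between measured compounds is available for this change. On the two numbers shown, the expected step from compound 2 to compound 3, a number 7 percentage points lower from compound 2 to compound 3 (within the scatter), is small and downward, not beyond the scatter. Compound 3 is thus expected to give about 71% in this assay, with a range from 56% to 86%.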

Compound 3, percent growth inhibition at one concentration: 73%
Compound 3: the middle estimate sits 2 percentage points below what was measured; the range from low to high includes it.
By their numbers in this assay, from the lowest: compounds 1, 3 and 2 (each within the scatter of the next).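

In this assay, chloro in place of methoxy on an aromatic carbon para to a large group gives a number 5 percentage points lower from compound 2 to compound 3 (within the scatter) and so does not separate the two groups at this position. Phenyl in place of naphthalen-1-yl on the saturated chain carbon gives a number 5 percentage points higher from compound 1 to compound 3 (within the scatter), so compound 3 turns the double difference between compound 1 and compound 2 into two single changes, neither beyond the scatter. No measurement here bears on the reading of these two steps.

The compounds shown leave open whether an amine or a carboxylic acid in place of chloro or methoxy on that aromatic carbon would give a step beyond the scatter. They also leave open whether methoxy and chloro stay indistinguishable with naphthalen-1-yl on the chain, since only chloro is shown with that group.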